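The source may report more compounds than this note shows. Statements on the series, on what has been measured and on what is new or still open speak of the compounds shown alone.

Working notes on the series. Two members have been run in a functional assay on the whole organism for inhibition, with Rattus norvegicus as the target, read by paw edema, with a stated time of 30 min, at a dose of 40 mg/kg by the oral route; on this read-out lower numbers stand for a weaker effect and higher numbers for a stronger effect at the one dose given. Compound 1, `COc1ccc(OCC2=NCCO2)cc1`, gives 33.2% in this assay. Compound 2, `Clc1ccc(OCC2=NCCO2)cc1`, gives 48.2%. Among the measured compounds shown here, the single measured step, chloro in place of methoxy on an aromatic carbon, reads a number 15 percentage points higher from compound 1 to compound 2 (beyond the scatter). For the measured compounds named here, compound 2 therefore holds the higher of the two numbers so far, with compound 1 as its only neighbour and that one beyond the scatter below it.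

The next member, compound 3, `Cc1cc(OCC2=NCCO2)ccc1Cl`, is to be measured in this assay. Its difference from compound 2 is methyl in place of hydrogen on an aromatic carbon. Going by the values given here, no measured step tests a methyl entering in place of hydrogen; the only step available concerns the exchange of methoxy for chloro and does not bear on this change. The chloro group of compound 2 is retained in compound 3, so the value of compound 2, 48.2%, is the reference. With nothing to argue for a shift either way, the expected step is a number 0.8 percentage points higher from compound 2 to compound 3 (within the scatter), that is, none beyond the scatter. Compound 3 is estimated at 49%, with a range from 34% to 64%.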

Compound 3, a percentage reported as inhibition, in the whole organism at one dose (the size of the read-out at that dose, not a potency): 45.4%
Estimate against measurement, compound 3: 3.6 percentage points above; low and high end bracket the measured number.
By their numbers in this assay, from the lowest: compound 1; then compounds 3 and 2 (each within the scatter of the next).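

Among the compounds shown here, the first methyl step sits on an aromatic carbon ortho to a chloro group and meta to a group of 7 heavy atoms, and in this assay methyl in place of hydrogen gives a number 2.8 percentage points lower from compound 2 to compound 3 (within the scatter). At this one oral dose, the position therefore accepts a methyl without a change beyond the scatter, something the earlier exchange of methoxy for chloro could not show, as it concerned a different change. Nothing available explains why the read-out holds when this methyl enters.

The compounds shown leave open whether the position would accept more than a single carbon, for example an ethyl group, a primary amine or a carboxylic acid, in place of the methyl of compound 3. They also leave open whether compound 2 and compound 3 would remain within the scatter of each other at other doses or times, since a single-dose percentage gives the size of the read-out at that dose and not a potency.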